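The source may report more compounds than this note shows. Statements on the series, on what has been measured and on what is new or still open speak of the compounds shown alone.

Of the compounds shown here, three have so far been measured in a functional assay on K562 cells (Homo sapiens) for cytotoxicity, read by MTT assay, with a stated time of 72 h; on this read-out higher numbers stand for weaker inhibition and lower numbers for stronger inhibition. Compound 1, `CC(C)(C)C1=CC(=O)C=C(NCC(=O)O)C1=O`, has the simplest structure of the set; in this assay compound 1 gives 85000 nM, the highest of the three numbers. Compound 3, `CC1=CCC[C@H]2[C@](C)(CC3=CC(=O)C=C(NCC(=O)O)C3=O)[C@@H](C)CC[C@]12C`, carries a far larger core, and in this assay compound 3 gives 15600 nM. Compound 2, `CC1=CCC[C@H]2[C@](C)(CC3=CC(=O)C=C(N[C@@H](CC(C)C)C(=O)O)C3=O)[C@@H](C)CC[C@]12C`, shares that larger core, and in this assay compound 2 gives 11200 nM. The gap between compound 1 and compound 3 lies beyond the usual scatter of the measurement, but how the two cores differ is not broken down here.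

Compound 2 differs from compound 3 in one place only: isobutyl in place of hydrogen on a saturated chain carbon bound to an amine nitrogen and a carbonyl carbon. The step this change made is a 1.4-fold lower number from compound 3 to compound 2 (0.14 log units; within the scatter), so small that the two compounds cannot be told apart on this read-out.

Compound 4, `CC(C)C[C@H](NC1=CC(=O)C=C(C(C)(C)C)C1=O)C(=O)O`, has not yet been measured. It carries the same change, placed on the core of compound 1: isobutyl in place of hydrogen on a saturated chain carbon bound to an amine nitrogen and a carbonyl carbon. Among the compounds shown this change occurs twice, at the same place each time. Because the measured step of a 1.4-fold lower number from compound 3 to compound 2 (0.14 log units; within the scatter) stayed within the scatter, the step of a 1.4-fold lower number from compound 1 to compound 4 (0.15 log units; within the scatter) is expected to be similarly small. Compound 4 is therefore estimated to give 60000 nM in this assay, most likely between 25000 nM and 150000 nM.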

Compound 4, half-maximal inhibitory concentration: 76500 nM
Estimate against measurement, compound 4: 1.3-fold (0.11 log units) below; measured number inside the range.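

With the isobutyl group in place of hydrogen on the core of compound 1, this assay gives a 1.1-fold lower number from compound 1 to compound 4 (0.05 log units; within the scatter), so the two compounds cannot be told apart on this read-out. Set beside the earlier step, the result shows that this change behaves alike on the two cores, with neither step large enough to stand out from the scatter: the same change on two cores in this assay, a 1.4-fold lower number (0.14 log units; within the scatter) from compound 3 to compound 2 and a 1.1-fold lower number (0.05 log units; within the scatter) from compound 1 to compound 4, 1.3-fold (0.10 log units) apart, within the scatter of two such steps. Among the compounds shown here, this agreement rests on only two pairs in a single assay, so it does not show that the change would stay as small on any other core, and it does not explain why the step is small on these two.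

From the compounds shown here alone, only hydrogen and isobutyl are compared on this saturated chain carbon, so it remains open whether another group there, such as a benzyl group, a hydroxymethyl group or a longer chain, would give a step beyond the scatter. The acid group also stays the same in all the compounds shown, which leaves open what a methyl ester or an amide in its place would do to the number on either core.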